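The compounds below may be only part of what the source reports. "The series", "measured", "known", "first", "only" and "open" are said of these compounds alone.

In an ADME assay on HEK-293T cells (Homo sapiens) for cytotoxicity, read by CCK-8 assay, with a stated time of 48 h (a lower number here means a stronger inhibitor, a higher number a weaker inhibitor), compound 1 `COc1ccc(NC(=O)NCCNS(=O)(=O)c2ccc(-c3ccccc3OCc3ccccc3)s2)cc1` reads > 50000 nM as a limit of the assay and not a number. Compound 3 `COc1ccc(NC(=S)NCCNS(=O)(=O)c2sccc2-c2ccc(C)cc2Oc2ccc(O)c(O)c2)cc1` likewise reads > 20000 nM as a limit. Among the compounds with values here, compound 2 `O=C(NCCNS(=O)(=O)c1ccc(-c2ccccc2O[C@H]2CC[C@@H](O)CC2)s1)Nc1ccc([N+](=O)[O-])cc1` gives 8600 nM as the only true number so far. Compound 4 `O=C(NCCNS(=O)(=O)c1ccc(-c2ccccc2OCc2ccccc2)s1)Nc1cccc([N+](=O)[O-])c1` has 3-nitrophenyl in place of 4-methoxyphenyl on an amide-type nitrogen of compound 1, counted as 3-nitrophenyl in place of 4-methoxyphenyl on an amide-type nitrogen for this exchange. Within the data shown here, no step between measured compounds tests this change. Compound 2 also carries a nitrophenyl group on an amide-type nitrogen and gives 8600 nM in a different molecule, so a moderate move toward stronger inhibition in this assay is expected. The expected change is an at least 2.5-fold lower number from compound 1 to compound 4 (0.39 log units; beyond the scatter) by this estimate. Compound 4 is estimated at 20000 nM with an expected range from 6000 nM to 50000 nM when measured.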

Compound 4, half-maximal inhibitory concentration: 13300 nM
For compound 4 the middle estimate is 1.5-fold (0.18 log units) above the measured one; low and high end bracket the measured number.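

In this assay, within the data shown here, putting 3-nitrophenyl in place of 4-methoxyphenyl on an amide-type nitrogen gives an at least 3.7-fold lower number from compound 1 to compound 4 (0.57 log units; beyond the scatter), the first step at this position and one beyond the scatter. It shows that this exchange alone, with the rest of the core of compound 1 unchanged, brings a measurable reading. Compound 1 sits at a limit of the assay and not a number: the limit of > 50000 nM in this assay, at which 1 of the 4 values shown sits.

The compounds shown do not tell whether the step follows from the nitro group itself or from its ring position. Going by these compounds, how an unsubstituted phenyl, 3-aminophenyl or 3-carboxyphenyl would read on that nitrogen also stays open.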